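The source may report more compounds than this note shows. Statements on the series, on what has been measured and on what is new or still open speak of the compounds shown alone.

Measured so far in a functional assay on the whole organism (stomach) for inhibition, with Rattus norvegicus as the target, at a dose of 100 mg/kg by the intraduodenal route; on this read-out lower numbers stand for less inhibition and higher numbers for more inhibition at the one dose given (going by the name of the read-out):
- compound 1 `N=C(S)CCCn1nc(-c2ccccc2)ccc1=O`: 75.6%
- compound 2 `CC(CC(=N)S)n1ncccc1=O`: 38.8%
- compound 3 `Cc1ccc(=O)n(CCCC(=N)S)n1`: 36.3%

Compound 1 stands highest of the three numbers; compound 2 and compound 3 both lie beyond the scatter below it. Within the data shown here, the one single-point step, a number 39.3 percentage points lower from compound 1 to compound 3 (beyond the scatter), concerns methyl in place of phenyl on an aromatic carbon. Compound 2 differs from compound 1 in more than one place, so only its value is noted.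

Compound 4 `CN(C)C(=S)CCn1nc(-c2ccccc2)ccc1=O` is not yet measured. It differs from compound 1 as follows: a group of 5 heavy atoms (3 carbon, 1 nitrogen, 1 sulfur; no ring) in place of a group of 4 heavy atoms (2 carbon, 1 nitrogen, 1 sulfur; no ring), on a saturated chain carbon, two bonds along the chain from an aromatic nitrogen. Among the measured compounds shown here, the change keeps the phenyl that compound 3 lacks, so the step from compound 1 to compound 3 does not bear on it; no measured step in this assay touches the chain or the group at its end. The expectation therefore rests on compound 1 alone, with wide uncertainty, centered somewhat below compound 1 as the nearest measured value. The expected step is a number 20.6 percentage points lower from compound 1 to compound 4 (beyond the scatter). Compound 4 is estimated at 55%, with a range from 25% to 80%.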

Compound 4, a percentage reported as inhibition, in the whole organism at one dose (the size of the read-out at that dose, not a potency): 46%
Compound 4: middle estimate off by 9 percentage points, on the high side, and the stated range covers the measured number.
By their numbers in this assay, from the lowest: compounds 3, 2 and 4 (each within the scatter of the next); then compound 1.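

In this assay the place on a saturated chain carbon, two bonds along the chain from an aromatic nitrogen, now proves sensitive with the phenyl kept: the step reads a number 29.6 percentage points lower from compound 1 to compound 4 (beyond the scatter). The group at this place therefore counts in this read-out at the one dose given, separately from the methyl in place of phenyl change, and the group of 5 heavy atoms, with 0 hydrogen-bond donors against 2 in the group it replaces, does not hold the level of compound 1. No measurement shown bears on the reason for this drop.

This single step changes the heavy atoms and the donor count together, so the compounds shown do not separate the two. Also open, from the compounds shown here alone, is how a carboxylic acid, a primary amide or a longer chain at this place would read with the phenyl kept.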